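Chloro to methyl on the fused ring: expected cytotoxicity

The source may report more compounds than this note shows. Statements on the series, on what has been measured and on what is new or still open speak of the compounds shown alone.

Measured so far:
compound 1 `Cc1cc(-c2nc3ccccc3o2)ccc1NC(=O)CCl`: in a functional assay on HT-29 cells (Homo sapiens) for cytotoxicity, read by MTT assay, with a stated time of 24 h (on this read-out higher numbers stand for weaker inhibition and lower numbers for stronger inhibition), compound 1 gives 13800 nM
compound 2 `Cc1cc(-c2nc3cc(Cl)ccc3o2)ccc1NC(=O)CCl`: in this assay compound 2 gives > 100000 nM

Compound 2 holds the weaker of the two entries, but its entry is a limit of the assay and not a number (the limit of > 100000 nM in this assay, at which 1 of the 2 values shown sits), so how far it sits beyond compound 1 is not known. Within the data shown here, the one measured step here is an at least 7.2-fold higher number from compound 1 to compound 2 (0.86 log units; beyond the scatter), a clear loss on adding chloro to the fused ring.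

Compound 3 `Cc1ccc2oc(-c3ccc(NC(=O)CCl)c(C)c3)nc2c1` differs from compound 2 by methyl in place of chloro on an aromatic carbon. Among the measured compounds shown here, no measured step exchanges chloro for methyl at this place; the step of an at least 7.2-fold higher number from compound 1 to compound 2 (0.86 log units; beyond the scatter) bears on it only indirectly, showing that a substituent at this position weakened inhibition against hydrogen. Whether methyl behaves like chloro or like hydrogen cannot be told from these two compounds, so the expectation is a value between them, weighted toward compound 2, with a wide range. The expected step is an at least 2.0-fold lower number from compound 2 to compound 3 (0.30 log units; that floor lies within the scatter) and is uncertain in direction. In this assay the estimate for compound 3 is 50000 nM, with an expected range from 10000 nM to 200000 nM.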

Compound 3, half-maximal inhibitory concentration: 13800 nM
For compound 3 the middle estimate is 3.6-fold (0.56 log units) above the measured one; the range from low to high includes it.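

In this assay, methyl at this place on the fused ring is tolerated as well as hydrogen: no change at the digits printed from compound 1 to compound 3 (within the scatter). The loss seen with chloro is therefore not common to every substituent at this place, since exchanging chloro for methyl gives an at least 7.2-fold lower number from compound 2 to compound 3 (0.86 log units; beyond the scatter), and across these three compounds only the chloro compound falls out of the measurable range. The entry for compound 2 is a limit of the assay and not a number, so the true size of that step stays unknown and only its floor can be read: the limit of > 100000 nM in this assay, at which 1 of the 3 values shown sits.

With one chloro and one methyl compound, these data cannot show whether the loss belongs to chloro alone or extends to other groups at this place, and they give no reason for the difference between the two groups. An amine, a methoxy group or a carboxylic acid on the same aromatic carbon, or a longer chain such as ethyl in place of methyl, would show whether the tolerance seen with methyl reaches beyond that single group.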